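The compounds below may be only part of what the source reports. "The series", "measured", "known", "first", "only" and "open" are said of these compounds alone.

Measured so far in an ADME assay on L6 cells (Rattus norvegicus) for cytotoxicity; a lower number here means a stronger inhibitor, a higher number a weaker inhibitor:
- compound 1 `Cc1nc(-c2ccccn2)nc(NCc2ccccc2)c1Cl` gives 70100 nM 
- compound 2 `Cc1nc(-c2ccccn2)nc(NCCCc2ccccc2)c1Cl` gives 73500 nM 

These two values lie within the usual scatter of each other, so compound 1 holds no separate rank on these numbers. The next compound to be tested is compound 3 `Cc1nc(-c2ccccn2)nc(NCc2ccc(S(C)(=O)=O)cc2)c1Cl`, which keeps everything in compound 1 but carries methylsulfonyl in place of hydrogen on an aromatic carbon, para to a large group (methylsulfonyl in place of hydrogen on an aromatic carbon).

Among the compounds with values here, only one measured step is available for comparison: a 1.0-fold higher number from compound 1 to compound 2 (0.02 log units; within the scatter). It is a small step, but it places phenethyl in place of phenyl on a saturated chain carbon, so it concerns a different place from the aromatic carbon changed in compound 3. Within the data shown here, no measured compound carries methylsulfonyl, which leaves the data without a direction for this change. The working expectation in this assay is therefore no step beyond the scatter, held with wide uncertainty. The estimated change is a 1.1-fold higher number from compound 1 to compound 3 (0.06 log units; within the scatter) and should be read as a rough guess. For compound 3 the expected value is 80000 nM (range 35000 nM to 180000 nM).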

Compound 3, half-maximal inhibitory concentration: 93600 nM
Compound 3: the middle estimate sits 1.2-fold (0.07 log units) below what was measured; the measured number falls inside the stated range.
By their numbers in this assay, from the lowest: compounds 1, 2 and 3 (each within the scatter of the next).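

In this assay, methylsulfonyl in place of hydrogen on an aromatic carbon, para to a large group, gives a 1.3-fold higher number from compound 1 to compound 3 (0.13 log units; within the scatter), so this change cannot be told apart from no change at all. Within the data shown here, the earlier step from compound 1 to compound 2 concerned a saturated chain carbon, so this is the first reading at this aromatic position, and it shows that adding 4 heavy atoms there, with 2 hydrogen-bond acceptors among them, leaves the number within the usual spread of repeat measurements. Nothing available explains this outcome or shows what the added group does in these cells.

A single group at a single place cannot show whether this aromatic carbon would give the same result with a different group, such as an amine or a carboxylic acid. From the compounds shown here alone, it also remains open whether methylsulfonyl would give the same result on another carbon of that ring, or whether combining it with the longer chain of compound 2 would move the number beyond the scatter.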